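The source may report more compounds than this note shows. Statements on the series, on what has been measured and on what is new or still open speak of the compounds shown alone.

Of the compounds shown here, two sharing the same core have been tested in an assay on isolated protein for inhibition of aldehyde dehydrogenase 1A1 (Homo sapiens), read by spectrophotometry, tested at 10 uM; a lower number here means less inhibition, a higher number more inhibition at the concentration tested (going by the name of the read-out). Compound 1 `CCc1ccc(C(=O)N2CCN(Cc3nc4ccccc4n3Cc3cccc(C)c3)CC2)cc1` gives 67% in this assay, the higher of the two numbers. Compound 2 `O=C(C1CC1)N1CCN(Cc2nc3ccccc3n2Cc2ccccc2)CC1` gives 23.9%, a number that lies well beyond the usual scatter below that of compound 1. Compound 2 differs from compound 1 in more than one place, so its values alone do not isolate any single change.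

The untested compound 3 `Cc1cccc(Cn2c(CN3CCN(C(=O)C4CCCCC4)CC3)nc3ccccc32)c1` differs from compound 1 in one place: cyclohexyl in place of 4-ethylphenyl on a carbonyl carbon. Within the data shown here, no measured pair shows this change on its own. Because compound 2, which also carries a non-aromatic ring on the carbonyl carbon, gives 23.9%, a loss of inhibition is expected, though of smaller size, as the ring entering in compound 3 is larger. The step from compound 1 to compound 3 is estimated at a number 22 percentage points lower from compound 1 to compound 3 (beyond the scatter). Compound 3 is expected to give 45%, within a range from 25% to 65%.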

Compound 3, a percentage reported as inhibition, at one concentration (the size of the read-out at that concentration, not a potency): 31.9%
Beside the measured number, compound 3's estimate is 13.1 percentage points above it; measured number inside the range.
By their numbers in this assay, from the lowest: compounds 2 and 3 (each within the scatter of the next); then compound 1.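

In this assay, among these compounds, the step of a number 35.1 percentage points lower from compound 1 to compound 3 (beyond the scatter) is the first measured change made at one place alone, and it shows that the group on this carbonyl carbon matters for inhibition at the concentration tested. With everything else in compound 1 held constant, a 4-ethylphenyl group cannot be replaced by cyclohexyl without a large loss. No measurement shown gives a reason for this loss.

This change removes the aromatic ring and the ethyl group together, so the compounds shown cannot tell which of the two accounts for the step. A plain phenyl group on the same carbonyl carbon would separate these two parts, while a longer chain such as 4-butylphenyl would show whether the size of the group on the ring makes any difference.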